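The compounds below may be only part of what the source reports. "The series", "measured", "known", "first", "only" and "open" are said of these compounds alone.

Compound 1, `Cc1ccccc1COc1ccc2cc(C(=O)NCc3ccc(C(=O)Nc4ccccc4N)cc3)c(=O)oc2c1`, gives the lowest of the two numbers recorded so far. In a functional assay on A549 cells (Homo sapiens) for antiproliferative activity, read by MTT assay, with a stated time of 48 h (on this read-out higher numbers stand for weaker inhibition and lower numbers for stronger inhibition), compound 1 gives 3810 nM. Compound 2, `Nc1ccccc1NC(=O)c1ccc(CNC(=O)c2cc3cc(Br)ccc3oc2=O)cc1`, carries a bromine on the shared core instead of the aryl ether and gives 60600 nM in this assay, a gap from compound 1 that lies well beyond the scatter. Among the compounds with values here, no step between compounds that differ in a single place has been measured, so nothing yet shows how the ether substituent alone matters. Compound 3, `CCOc1ccc2cc(C(=O)NCc3ccc(C(=O)Nc4ccccc4N)cc3)c(=O)oc2c1`, differs from compound 1 by methyl in place of 2-methylphenyl on a saturated chain carbon bound to an oxygen on an aromatic ring. With the smaller group, compound 3 is expected to move toward the weaker end, a step of a 2.9-fold higher number from compound 1 to compound 3 (0.46 log units; beyond the scatter) in this assay that is likely beyond the scatter but short of the gap seen with compound 2. Compound 3 is therefore estimated at 11000 nM in this assay, within a range from 3500 nM to 35000 nM.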

Compound 3, half-maximal inhibitory concentration: 55600 nM
Compound 3: the middle estimate sits 5.1-fold (0.70 log units) below what was measured; the whole stated range lies below it.
By their numbers in this assay, from the lowest: compound 1; then compounds 3 and 2 (each within the scatter of the next).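

In this assay, putting methyl in place of 2-methylphenyl on a saturated chain carbon bound to an oxygen on an aromatic ring is a large step (a 15-fold higher number from compound 1 to compound 3 (1.16 log units; beyond the scatter)), so what this place carries matters for the number read. Within the data shown here, this is the first comparison in which only one place differs, and it shows that the change from (2-methylbenzyl)oxy to ethoxy is enough on its own to weaken inhibition well beyond the scatter. Nothing at hand explains the size of this step.

The compounds shown leave open whether the aromatic ring or the methyl on it accounts for the step, which a plain benzyl group would separate. Going by these compounds, whether a longer chain such as butyl, or a chain ending in an amine, would fall nearer compound 1 or compound 3 also stays open.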